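The source may report more compounds than this note shows. Statements on the series, on what has been measured and on what is new or still open speak of the compounds shown alone.

In a functional assay on THP-1 cells (Homo sapiens) for cytotoxicity, read by MTT assay, with a stated time of 24 h (a lower number here means a stronger inhibitor, a higher number a weaker inhibitor), compound 1 `COc1cc(/C=C2\CN(C)C/C(=C\c3ccc(Cl)cc3)C2=O)cc(OC)c1` gives 5860 nM. In this assay compound 2 `COc1cc(/C=C2\CN(C)C/C(=C\c3ccc(Br)cc3)C2=O)cc(OC)c1` gives 4270 nM. In this assay compound 3 `CN1C/C(=C\c2ccc(Cl)cc2)C(=O)/C(=C/c2cccc([N+](=O)[O-])c2)C1` gives 7870 nM.

Compound 1 and compound 2 share one core and differ in a single place: bromo in place of chloro on an aromatic carbon. In this assay this change gave a 1.4-fold lower number from compound 1 to compound 2 (0.14 log units; within the scatter), so the two numbers lie within the scatter of each other and no order between them can be read.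

Compound 3 stands on a different core; the difference between the core of compound 1 and the core of compound 3 is not broken down here. Its value is within the scatter of both compound 1 and compound 2.

Compound 4 `CN1C/C(=C\c2ccc(Br)cc2)C(=O)/C(=C/c2cccc([N+](=O)[O-])c2)C1` is not yet measured. It differs from compound 3 in exactly the way compound 2 differs from compound 1: bromo in place of chloro on an aromatic carbon. The place description is the same word for word in both pairs, so this is the same change carried onto the core of compound 3. Nothing in the data suggests the new core should respond differently to it.

For the measured compounds named here, the expectation for compound 4 therefore rests on the single measured instance of this change, the step of a 1.4-fold lower number from compound 1 to compound 2 (0.14 log units; within the scatter), which was small. The step expected from compound 3 to compound 4 in this assay is accordingly a 1.4-fold lower number from compound 3 to compound 4 (0.14 log units; within the scatter), again within the scatter. Compound 4 is estimated to give 5700 nM in this assay, with a likely range from 2800 nM to 11500 nM.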

Compound 4, half-maximal inhibitory concentration: 7690 nM
Compound 4: the middle estimate sits 1.3-fold (0.13 log units) below what was measured; the measured number falls inside the stated range.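

Carried onto the core of compound 3, bromo in place of chloro gave in this assay a 1.0-fold lower number from compound 3 to compound 4 (0.01 log units; within the scatter), so no order can be read between the two numbers. Set beside the earlier pair, the step on this core does not stand apart from the step on the first core: the same change on two cores in this assay, a 1.4-fold lower number (0.14 log units; within the scatter) from compound 1 to compound 2 and a 1.0-fold lower number (0.01 log units; within the scatter) from compound 3 to compound 4, 1.3-fold (0.13 log units) apart, within the scatter of two such steps. This shows that, in this assay, the change from 4-chlorophenyl to 4-bromophenyl produced no step beyond the scatter on either core, but it does not show that the change is without any effect or that the two cores respond identically, as two small steps, each within the scatter, could hide a real difference and two pairs are too few to establish a rule for the series.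

The compounds shown leave open whether a group other than these two halogens at this place, such as an amine or a carboxylic acid, would produce a step that could be read beyond the scatter. They also leave open what a longer chain in place of the methyl group on the shared ring nitrogen would do to the number in this assay.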